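This account rests on a few compounds, and the source may have more. Where it says the series, first, only, none or still open, it means among the compounds named here.

Measured compounds:
- compound 1, `COc1ccc(-n2c(SC(C)C(=O)Nc3nc(C)cs3)nc3ccccc32)cc1`: "not determined" (no result reported)
- compound 2, `COc1ccc(-n2c(SC(C)C(=O)Nc3ccc(C)cc3Cl)nc3ccccc32)cc1`: > 75000 nM

Both compounds share the same core and differ only in the aryl group on the amide nitrogen. In an ADME assay on Vero cells (Chlorocebus sabaeus) for cytotoxicity, read by MTT assay, with a stated time of 24 h (a higher number here means that more compound is tolerated, a lower number that less compound is tolerated), compound 1 has no result. For compound 2 the value is a limit of the assay, not a number: compound 2 tolerates the highest amount tested without reaching half-maximal cell death. This is captured by the limit of > 75000 nM in this assay, at which 1 of the 2 values shown sits, which shows where compound 2 stands.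

Compound 3, `COc1ccc(-n2c(SC(C)C(=O)Nc3ncc(C)cc3Cl)nc3ccccc32)cc1`, has not yet been measured. It differs from compound 2 by 3-chloro-5-methylpyridin-2-yl in place of 2-chloro-4-methylphenyl on an amide-type nitrogen, so 3-chloro-5-methylpyridin-2-yl in place of 2-chloro-4-methylphenyl on an amide-type nitrogen. Going by the values given here, no step between two measured compounds exists to calibrate this change, so there is no basis to expect a shift beyond the scatter in this assay. The expected step, a step that the limit leaves unreadable from compound 2 to compound 3, stays within the usual scatter. Compound 3 is therefore estimated at 100000 nM, with a range from 40000 nM to 300000 nM, and most likely the assay will again report only a limit.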

Compound 3, half-maximal cytotoxic concentration: 880 nM
Estimate against measurement, compound 3: 110-fold (2.06 log units) above; measured number outside the range, below it.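

In this assay, putting 3-chloro-5-methylpyridin-2-yl in place of 2-chloro-4-methylphenyl on an amide-type nitrogen brings an at least 85-fold lower number from compound 2 to compound 3 (1.93 log units; beyond the scatter). This group on the amide-type nitrogen therefore matters greatly for how much compound the cells tolerate, even though the heavy-atom count stays the same and the entering ring differs by holding one ring nitrogen and one hydrogen-bond acceptor. Compound 2 is held only at a limit of the assay, so the step gives a minimum size and its full size stays unknown: the limit of > 75000 nM in this assay, at which 1 of the 3 values shown sits.

Compound 1 has no result, so steps involving it cannot be read, and this single pair cannot show why the number falls or whether the ring nitrogen would have the same effect on other aryl groups. From the compounds shown here alone, it also remains open how the number would respond to a pyridin-2-yl ring without the chlorine, or to an amine or a carboxylic acid in place of the methyl on the 3-chloro-5-methylpyridin-2-yl ring.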